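The source may report more compounds than this note shows. Statements on the series, on what has been measured and on what is new or still open speak of the compounds shown alone.

Working notes on the series. The shared core is seen in compound 1 `COc1cc2c(cc1OC)C(CC(=O)O)CC2`, which in a functional assay on the whole organism (strain Wistar) for inhibition, with Rattus norvegicus as the target, read by paw edema, with stated times of 60 min and 3 h, at a dose of 100 mg/kg by the oral route (a higher number here means more inhibition at the dose given (going by the name of the read-out), a lower number less inhibition), gives 27.5%. Compound 2 `COc1cc2c(cc1OC)C(CC(=O)N(C)C)CC2` gives 34.8% in this assay, and compound 3 `COc1cc2c(cc1OC)C(CC(=O)N1CCOCC1)CC2` gives 19.6%. Among these three numbers compound 3 stands lowest, nearest to compound 1 and furthest from compound 2, the latter gap being the only one beyond the scatter: a number 15.2 percentage points lower from compound 2 to compound 3 (beyond the scatter), whereas a number 7.9 percentage points lower from compound 1 to compound 3 (within the scatter) and a number 7.3 percentage points higher from compound 1 to compound 2 (within the scatter).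

The next step goes from compound 3 to compound 4 `COc1cc2c(cc1OC)C(CC(=O)NCCO)CC2`: (2-hydroxyethyl)amino in place of morpholin-4-yl on a carbonyl carbon. Within the data shown here, two measured steps bear on a change at the carbonyl carbon of compound 3: a number 7.9 percentage points lower from compound 1 to compound 3 (within the scatter), within the scatter, and a number 15.2 percentage points lower from compound 2 to compound 3 (beyond the scatter), modest but beyond it. Exchanging one amide substituent for another thus moved this assay by a modest amount at most, so for compound 4 a small step upward in this assay, within the scatter, is expected, namely a number 7.4 percentage points higher from compound 3 to compound 4 (within the scatter). Compound 4 is estimated at 27%, with a range from 14% to 40%.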

Compound 4, a percentage reported as inhibition, in the whole organism at one dose (the size of the read-out at that dose, not a potency): 12.3%
For compound 4 the middle estimate is 14.7 percentage points above the measured one; the measured number lies below the stated range.
By their numbers in this assay, from the lowest: compounds 4, 3, 1 and 2 (each within the scatter of the next, the first and the last beyond it).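

In this assay, (2-hydroxyethyl)amino on the carbonyl carbon stays within the scatter of morpholin-4-yl, as a number 7.3 percentage points lower from compound 3 to compound 4 (within the scatter) shows, but it separates beyond the scatter from the two other groups, in a number 22.5 percentage points lower from compound 2 to compound 4 (beyond the scatter) and in a number 15.2 percentage points lower from compound 1 to compound 4 (beyond the scatter). Among the earlier compounds, only dimethylamino and morpholin-4-yl stood apart beyond the scatter; now hydroxy also stands apart from an amide substituent at this position, and an open-chain group with a terminal hydroxy falls with the ring rather than with dimethylamino. Nothing available explains these steps.

The compounds shown leave open whether the terminal hydroxy or the amide hydrogen of (2-hydroxyethyl)amino goes with this separation. Methylamino, (2-methoxyethyl)amino and the longer (3-hydroxypropyl)amino would help to tell these apart.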